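The source may report more compounds than this note shows. Statements on the series, on what has been measured and on what is new or still open speak of the compounds shown alone.

The measured compounds:
compound 1, `COC(=O)C[C@H](NC(=O)OC(C)(C)C)C(=O)N(Cc1ccccc1)C1(C(=O)NCc2ccccc2)CCN(Cc2ccccc2)CC1`, > 100000 nM;
compound 2, `COC(=O)C[C@H](NC(=O)OC(C)(C)C)C(=O)N(C)C1(C(=O)NCc2ccccc2)CCN(Cc2ccccc2)CC1`, 20000 nM.

In an ADME assay on MDCK cells (Canis lupus familiaris) for cytotoxicity, read by microscopy, with a stated time of 72 h (a lower number here means that less compound is tolerated, a higher number that more compound is tolerated), compound 1 gives > 100000 nM, a limit of the assay rather than a number (the limit of > 100000 nM in this assay, at which 1 of the 2 values shown sits). Within the data shown here, compound 2 gives 20000 nM in this assay and so holds the only plain number among the two values shown. Among the measured compounds shown here, the one measured step is an at least 5.0-fold lower number from compound 1 to compound 2 (0.69 log units; beyond the scatter), so taking the larger group off that nitrogen lowered the tolerated concentration.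

Compound 3, `COC(=O)C[C@H](NC(=O)OC(C)(C)C)C(=O)N(C1CC1)C1(C(=O)NCc2ccccc2)CCN(Cc2ccccc2)CC1`, has not been measured. It differs from compound 2 by cyclopropyl in place of methyl on an amide-type nitrogen. For the measured compounds named here, the single measured step bears on this only indirectly: it concerns the same amide-type nitrogen and shows a lower number when a larger group is replaced by a smaller one. The change to compound 3 runs the other way, enlarging the group, but by far less than the phenyl removed in that step. A modestly higher number is therefore expected for compound 3, a 1.6-fold higher number from compound 2 to compound 3 (0.20 log units; within the scatter), quite possibly within the scatter. The value of compound 3 in this assay is estimated at 32000 nM, between 15000 nM and 80000 nM.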

Compound 3, minimum cytotoxic concentration: 84000 nM
Beside the measured number, compound 3's estimate is 2.6-fold (0.42 log units) below it, and the stated range ends below it.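

In this assay, cyclopropyl in place of methyl on the amide-type nitrogen gives a 4.2-fold higher number from compound 2 to compound 3 (0.62 log units; beyond the scatter), so a change far smaller than the loss of the phenyl also moves the number beyond the scatter, and of the three groups on this nitrogen, methyl gives the lowest number. Against benzyl, cyclopropyl gives an at least 1.1-fold lower number from compound 1 to compound 3 (0.07 log units; that floor lies within the scatter), but this is only a floor and the true gap may be wider, so it does not show that cyclopropyl matches benzyl. The value of compound 1 is a limit of the assay and not a number: the limit of > 100000 nM in this assay, at which 1 of the 3 values shown sits.

Going by these compounds, it remains open whether the ring of cyclopropyl matters or only the added carbons, a question that an open chain such as ethyl or isopropyl on this nitrogen could address. Also unanswered is how the number would respond to the amide hydrogen in place of any carbon group, or to a longer chain ending in an amine or a carboxylic acid.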